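Working notes: formyl in place of anilino

The compounds below may be only part of what the source reports. "The series", "measured", "known", "first", "only" and "open" are said of these compounds alone.

In an assay on isolated protein (strain Sprague-Dawley) for inhibition of Amine oxidase [flavin-containing] A (Rattus norvegicus), read by spectrophotometry, with a stated time of 5 min, tested at 10 uM (on this read-out lower numbers stand for less inhibition and higher numbers for more inhibition at the one concentration tested (going by the name of the read-out)), compound 1 `O=C(COc1cc(=O)oc2cc(OCc3cccc(Cl)c3)ccc12)N1CCCCC1` gives 9%. Compound 2 `O=c1cc(Nc2ccccc2)c2ccc(OCc3cccc(Cl)c3)cc2o1` gives 0% in this assay, the lowest of the two numbers, with compound 1 nearest. Going by the values given here, the only measured step is a number 9 percentage points lower from compound 1 to compound 2 (within the scatter). Compound 3 `O=Cc1cc(=O)oc2cc(OCc3cccc(Cl)c3)ccc12` differs from compound 2 by formyl in place of anilino on an aromatic carbon. That one step bears on this change only in that it also swapped the group on the same aromatic carbon, and it stayed within the scatter, so no move beyond the scatter is expected in this assay; the estimated step is a number 10 percentage points higher from compound 2 to compound 3 (within the scatter). Compound 3 is expected to give 10%, in the range 0% to 30%.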

Compound 3, a percentage reported as inhibition, at one concentration (the size of the read-out at that concentration, not a potency): 14%
Compound 3: middle estimate off by 4 percentage points, on the low side; measured number inside the range.
By their numbers in this assay, from the lowest: compounds 2, 1 and 3 (each within the scatter of the next, the first and the last beyond it).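

In this assay, going by these compounds alone, the change on this aromatic carbon opposite the ring oxygen gives a number 14 percentage points higher from compound 2 to compound 3 (beyond the scatter) and is the first step beyond the scatter, so formyl and anilino can be told apart here. Formyl and ((piperidin-1-yl)carbonyl)methoxy cannot be told apart, with a number 5 percentage points higher from compound 1 to compound 3 (within the scatter) as their step. No measurement at hand accounts for either step. On these data alone, whether a carboxylic acid or a primary amine on this carbon would give a higher number remains open. Potency also remains open, as the read-out gives no potency.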